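The source may hold more compounds than are shown below. What is called first, only, known or untested is meant among the compounds shown, and "the series" means these compounds.

The measured compounds in an ADME assay on MT4 cells (Homo sapiens) for cytotoxicity, read by MTT assay, with a stated time of 96 h; a higher number here means that more compound is tolerated, a lower number that less compound is tolerated:

compound 1, `O=C(O)CCC(=O)Nc1ccc(-c2nc3cc(C(F)(F)F)ccc3[nH]2)cc1`: > 100000 nM, which is a limit of the assay rather than a number
compound 2, `O=C(CN1CCCCC1)Nc1ccc(-c2nc3ccccc3[nH]2)cc1`: 31000 nM
compound 3, `O=C(CN1CCCC1)Nc1ccc(-c2nc3cc(C(F)(F)F)ccc3[nH]2)cc1`: 18000 nM

Compound 3 holds the lowest of the two plain numbers, but compound 2 sits within the scatter of it, so no order can be read between those two; the remaining value is a limit. Compound 4, `O=C(CN1CCCCC1)Nc1ccc(-c2nc3cc(C(F)(F)F)ccc3[nH]2)cc1`, has not yet been measured. It differs from compound 3 in one place: piperidin-1-yl in place of pyrrolidin-1-yl on a saturated chain carbon bound to a carbonyl carbon. For the measured compounds named here, the only measured step, an at least 5.5-fold lower number from compound 1 to compound 3 (0.74 log units; beyond the scatter), concerns a different exchange and so says little about swapping one saturated ring for another. Compound 2 carries the same piperidin-1-yl as compound 4 but lacks the trifluoromethyl of compound 4, so its value gives only a loose comparison. The step expected for a 1.1-fold higher number from compound 3 to compound 4 (0.05 log units; within the scatter) is therefore none beyond the scatter. Compound 4 is estimated to give 20000 nM in this assay, with a range from 9000 nM to 45000 nM.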

Compound 4, half-maximal cytotoxic concentration: 6000 nM
Estimate against measurement, compound 4: 3.3-fold (0.52 log units) above; the measured number lies below the stated range.
By their numbers in this assay, from the lowest: compound 4; then compounds 3 and 2 (each within the scatter of the next). At a limit, above all of these: compound 1.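

Exchanging pyrrolidin-1-yl for piperidin-1-yl on a saturated chain carbon bound to a carbonyl carbon gives, in this assay, a 3.0-fold lower number from compound 3 to compound 4 (0.48 log units; beyond the scatter) and so shows that these two saturated rings are not interchangeable at this position. Trifluoromethyl in place of hydrogen on an aromatic carbon can now be read on its own, as a 5.2-fold lower number from compound 2 to compound 4 (0.71 log units; beyond the scatter) with piperidin-1-yl held constant. Piperidin-1-yl in place of carboxymethyl gives an at least 16-fold lower number from compound 1 to compound 4 (1.22 log units; beyond the scatter) and this size is only a lower bound, since compound 1 stands at a limit of the assay and not at a number: the limit of > 100000 nM in this assay, at which 1 of the 4 values shown sits.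

Going by these compounds, whether the trend continues to a larger ring such as azepan-1-yl, or how an open-chain diethylamino group or a morpholin-4-yl ring would compare, remains open. Also open, on these data alone, is whether trifluoromethyl gives a step of similar size alongside pyrrolidin-1-yl.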